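The compounds below may be only part of what the source reports. "The series", "measured", "known", "first", "only" and "open" are said of these compounds alone.

In a functional assay on Jurkat cells (Homo sapiens) (a higher number here means a weaker inhibitor, a lower number a stronger inhibitor), compound 1 `CC(C)[C@H](NC(=O)COc1cccc2ccccc12)C(=O)N[C@@H](CC(=O)O)C(=O)COC(=O)c1c(Cl)cccc1Cl` gives 10600 nM in these notes. Compound 2 `CC(C)[C@H](NC(=O)COc1cccc2ccccc12)C(=O)N[C@@H](CC(=O)O)C(=O)COc1ccc(F)cc1F` gives 33200 nM in the same read-out, and the comparison is a 3.1-fold higher number from compound 1 to compound 2 (0.50 log units; beyond the scatter) on the group carried by the oxygen. Compound 3 `CC(C)[C@H](NC(=O)COc1cccc2ccccc12)C(=O)N[C@@H](CC(=O)O)C(=O)COc1ccc(F)c(F)c1` reads > 100000 nM as a limit of the assay and not a number. Compound 3 therefore stands at the limit of > 100000 nM in this assay, at which 1 of the 3 values shown sits, and lies at the weak end of the three. The steps leading to it are an at least 9.4-fold higher number from compound 1 to compound 3 (0.97 log units; beyond the scatter) and an at least 3.0-fold higher number from compound 2 to compound 3 (0.47 log units; beyond the scatter) and both lie beyond the scatter.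

Compound 4 `CC(C)[C@H](NC(=O)COc1cccc2ccccc12)C(=O)N[C@@H](CC(=O)O)C(=O)COc1cc(F)cc(F)c1` has 3,5-difluorophenyl in place of 3,4-difluorophenyl on an oxygen on a saturated carbon, counted as 3,5-difluorophenyl in place of 3,4-difluorophenyl on an oxygen on a saturated carbon with the rest of the structure unchanged. Within the data shown here, the nearest precedent is the only measured exchange of one difluorophenyl pattern for another, an at least 3.0-fold higher number from compound 2 to compound 3 (0.47 log units; beyond the scatter) in this assay here. That precedent shows that the fluorine pattern alone can shift the result, but a single pair sets no direction for this new pattern. Compound 4 is therefore expected to stay weak and near compound 3. The expected step is an at least 1.4-fold lower number from compound 3 to compound 4 (0.15 log units; that floor lies within the scatter) as estimated against a limit and is likely to be small. The estimate for compound 4 is 70000 nM with an expected range from 25000 nM to 200000 nM and a real chance of another limit reading.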

Compound 4, half-maximal inhibitory concentration: > 100000 nM
Compound 4 gave a limit, no number; the forecaster's own chance of this, stated with the estimate: 45%; middle value at least 1.4-fold (0.15 log units) from the limit.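

Moving the fluorines from the 3,4-difluorophenyl to the 3,5-difluorophenyl pattern on the oxygen on a saturated carbon gives no readable value in this assay, and compound 4 is a limit reading, as compound 3 is: the limit of > 100000 nM in this assay, at which 2 of the 4 values shown sit.

The step between these two compounds cannot be read, so the data give no order for the two patterns. Against the compounds with numeric readings, the new pattern shows an at least 3.0-fold higher number from compound 2 to compound 4 (0.47 log units; beyond the scatter) and an at least 9.4-fold higher number from compound 1 to compound 4 (0.97 log units; beyond the scatter), both beyond the scatter, which leaves the 2,4-difluorophenyl pattern as the only difluorophenyl pattern here with a numeric reading in this assay.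

Going by these compounds, three difluorophenyl patterns are too few to show which feature of the 2,4-difluorophenyl pattern separates it from the other two, and whether a 2,6-difluorophenyl or a 2,3,5,6-tetrafluorophenyl group on the same oxygen would also give a numeric reading remains open. Also open, on these data alone, is how far below the limit, if at all, the true values of compound 3 and compound 4 lie, which a more sensitive read-out would be needed to settle.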